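Ethyl to Cyclopropylmethyl Ester: Expecting a Small Shift

The source may hold more compounds than are shown below. What is called first, only, known or untested is meant among the compounds shown, and "the series" means these compounds.

For the measured compounds named here, compound 1 `CCOC(=O)c1ccc2[nH]c(NC(=O)OC)nc2c1` is the stronger of the two compounds measured so far in a functional assay on L1210 cells (Mus musculus) for inhibition (on this read-out lower numbers stand for stronger inhibition and higher numbers for weaker inhibition), where compound 1 gives 2800 nM. Compound 2 `COC(=O)Nc1nc2cc(C(=O)OCCC(C)C)ccc2[nH]1`, which carries a longer ester chain, gives 10000 nM, and the change along that chain, isopropyl in place of hydrogen on a saturated chain carbon two bonds along from an oxygen next to a carbonyl group, brings a 3.6-fold higher number from compound 1 to compound 2 (0.55 log units; beyond the scatter). So compound 1 stands at the lowest number of the pair. Compound 3 `COC(=O)Nc1nc2cc(C(=O)OCC3CC3)ccc2[nH]1` differs from compound 1 by cyclopropyl in place of methyl on a saturated chain carbon bound to an oxygen next to a carbonyl group. Going by the values given here, the only step that bears on this is the ester-chain growth in a 3.6-fold higher number from compound 1 to compound 2 (0.55 log units; beyond the scatter), a modest weakening; the cyclopropyl adds fewer atoms than the isopropyl, so a smaller rise is expected. For compound 3 the estimate in this assay is 4500 nM, between 1500 nM and 13000 nM, meaning an expected step of a 1.6-fold higher number from compound 1 to compound 3 (0.21 log units; within the scatter).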

Compound 3, half-maximal inhibitory concentration: 6900 nM
Beside the measured number, compound 3's estimate is 1.5-fold (0.19 log units) below it; the measured number falls inside the stated range.
By their numbers in this assay, from the lowest: compound 1; then compounds 3 and 2 (each within the scatter of the next).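

In this assay the ester with a ring on its chain also stands apart from compound 1, with a 2.5-fold higher number from compound 1 to compound 3 (0.39 log units; beyond the scatter) as ethyl gives way to cyclopropylmethyl, so the rise seen with compound 2 is not confined to a single open, branched chain. The two larger chains cannot be told apart at this place: the swap of isobutyl for cyclopropyl gives a 1.4-fold lower number from compound 2 to compound 3 (0.16 log units; within the scatter) and so the ring shows no separate effect here. Nothing available explains why either larger chain gives a higher number than ethyl.

The compounds shown leave open whether a methyl ester would give a lower number than compound 1. They also leave open how a carboxylic acid in place of the ester, or an amine at the end of the chain, would compare.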